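Shortening the ether chain from nonyl to methyl

The compounds below may be only part of what the source reports. "The series", "measured", "known", "first", "only" and "open" are said of these compounds alone.

Compound 2 `CCCCCCCCCOc1cc([N+](=O)[O-])ccc1NS(C)(=O)=O` is one of two compounds examined in an assay on SK-BR-3 cells for inhibition of Aromatase (Homo sapiens) (a lower number here means a stronger inhibitor, a higher number a weaker inhibitor), where compound 2 gives 910 nM. Going by the values given here, its only companion is compound 1 `CCCOc1cc([N+](=O)[O-])ccc1NS(C)(=O)=O`, which gives 2510 nM; the step between them, a 2.8-fold lower number from compound 1 to compound 2 (0.44 log units; beyond the scatter), leaves compound 2 with the lower of the two numbers. Compound 3 `COc1cc([N+](=O)[O-])ccc1NS(C)(=O)=O` has not yet been measured. It differs from compound 2 by hydrogen in place of octyl on a saturated chain carbon bound to an oxygen on an aromatic ring. Among the compounds with values here, the one measured step bears on this directly: it shows that lengthening the chain from compound 1 to compound 2 lowered the number, and compound 3 shortens the chain further than compound 1 does. Compound 3 is therefore expected to give a higher number than compound 2, a step of a 4.9-fold higher number from compound 2 to compound 3 (0.69 log units; beyond the scatter). The estimate for compound 3 is 4500 nM, in the range 1500 nM to 14000 nM.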

Compound 3, half-maximal inhibitory concentration: > 25000 nM
Compound 3 gave a limit, no number (the forecaster's own chance of this, stated with the estimate: 10%); middle value at least 5.5-fold (0.74 log units) away from the limit.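

Compound 3 reaches a limit of the assay, not a number: the limit of > 25000 nM in this assay, at which 1 of the 3 values shown sits.

Even so, the limit shows that the short end of this ether chain matters a great deal: hydrogen in place of octyl gives an at least 27-fold higher number from compound 2 to compound 3 (1.43 log units; beyond the scatter), and hydrogen in place of ethyl gives an at least 9.9-fold higher number from compound 1 to compound 3 (0.99 log units; beyond the scatter). Across these three compounds, the number in this assay rises each time the chain gets shorter, and no compound shown goes against this order.

Going by these compounds, the true value of compound 3 stays unknown, so both steps give only a minimum size. On these data alone, it also remains open whether a pentyl chain would fall between compound 1 and compound 2, and whether a chain longer than nonyl would lower the number further or reverse the trend.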